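Stilbene hydroxamates: thiophene replacing hydroxyphenyl

A few compounds are considered here, and "the series" means these few. Any claim that something is new, unique, unknown or untested is made for them only; others in the source may bear on it.

Measured so far:
Compound 1, `O=C(NO)c1cccc(/C=C/c2ccnc(-c3cc(F)ccc3O)c2)c1`, in an assay on isolated protein for inhibition of protein deacetylase HDAC6 (Homo sapiens), read by fluorescence, with a stated time of 15 min (on this read-out higher numbers stand for weaker inhibition and lower numbers for stronger inhibition), gives 400 nM.
Compound 2, `O=C(NO)c1ccc(/C=C/c2ccnc(-c3cccc(O)c3)c2)cc1`, in this assay gives 19 nM.

Compound 2 has the lower of the two numbers, and the gap to compound 1 is beyond the scatter. The next compound, compound 3 `O=C(NO)c1ccc(/C=C/c2ccnc(-c3ccsc3)c2)cc1`, has not yet been measured. Its change from compound 2: thiophen-3-yl in place of 3-hydroxyphenyl on an aromatic carbon. With a hydrogen-bond donor removed, a small step toward weaker inhibition is expected, a 2.4-fold higher number from compound 2 to compound 3 (0.37 log units; beyond the scatter). Compound 3 is expected to give 45 nM, estimated within 12 nM to 180 nM.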

Compound 3, half-maximal inhibitory concentration: 54 nM
The estimate for compound 3 lay 1.2-fold (0.08 log units) below the measured number; the measured number falls inside the stated range.
By their numbers in this assay, from the lowest: compound 2; then compound 3; then compound 1.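

In this assay, thiophen-3-yl in place of 3-hydroxyphenyl next to the ring nitrogen gives a 2.8-fold higher number from compound 2 to compound 3 (0.45 log units; beyond the scatter), a modest loss. The hydroxyl is therefore not essential for inhibition at this position: compound 3, with 0 hydrogen-bond donors on this ring, still gives 54 nM. The swap changes the ring and removes the hydroxyl at once, and no measurement here explains the step.

Still open, going by these compounds, is how much of the step belongs to the hydroxyl and how much to the ring. Unsubstituted phenyl would separate the two, and 3-aminophenyl would test another group here.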